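Swapping the Side Group on a Short-Lived Scaffold

A few compounds are considered here, and "the series" means these few. Any claim that something is new, unique, unknown or untested is made for them only; others in the source may bear on it.

Within the data shown here, compound 2 `CC(C)C(Nc1nccs1)c1ccc(-c2ccc3cccc(F)c3c2)[nH]c1=O` is the only one of the three compounds to give an actual number in an ADME assay on microsomes from liver (Homo sapiens) for metabolic stability (on this read-out higher numbers stand for a longer-lived compound and lower numbers for a shorter-lived compound), where compound 2 reaches 0.17 h. Compound 1 `CC(C)C(c1ncc[nH]1)c1ccc(-c2ccc3cccc(F)c3c2)[nH]c1=O` differs from it only at the side group on the saturated chain carbon. In this assay compound 1 returns < 0.0667 h, which is a limit of the assay rather than a number. Compound 3 `CCn1ncc2c(F)cc(-c3ccc(C(CC)(CC)c4nnc(C)[nH]4)c(=O)[nH]3)cc21` carries a different core. In this assay compound 3 returns > 3 h, again a limit. Among the measured compounds shown here, the one measured step, an at least 2.5-fold higher number from compound 1 to compound 2 (0.40 log units; beyond the scatter), is only a bound on the true change because its starting point is the limit of < 0.0667 h in this assay, at which 1 of the 3 values shown sits.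

Compound 4 `CC(C)C(/C=C1\CCNC1=O)c1ccc(-c2ccc3cccc(F)c3c2)[nH]c1=O` is the next candidate. Its change from compound 2 is a group of 7 heavy atoms (5 carbon, 1 nitrogen, 1 oxygen; one five-membered non-aromatic ring with 1 hetero atom) in place of a group of 6 heavy atoms (3 carbon, 2 nitrogen, 1 sulfur; one five-membered aromatic ring with 2 hetero atoms), on a saturated chain carbon bound to an aromatic carbon and a saturated chain carbon. For the measured compounds named here, this exchange removes the very group that the measured step introduced, so that step does not test the new group directly, and no measured pair here swaps an aromatic five-membered ring for a non-aromatic one. With no closer comparison available, the expectation for compound 4 in this assay is no step beyond the scatter, a 1.1-fold lower number from compound 2 to compound 4 (0.05 log units; within the scatter), with an estimated value of 0.15 h and a likely range from 0.05 h to 0.5 h.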

Compound 4, half-life: 0.713 h
For compound 4 the middle estimate is 4.8-fold (0.68 log units) below the measured one; the whole stated range lies below it.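

The side group on the saturated chain carbon can shift the half-life beyond the scatter while the rest of the molecule stays the same: in this assay, the group with the five-membered non-aromatic ring, in place of (1,3-thiazol-2-yl)amino, gives a 4.2-fold higher number from compound 2 to compound 4 (0.62 log units; beyond the scatter). An aromatic five-membered ring is therefore not required at this place, and among the three side groups shown on this shared core, the non-aromatic ring group gives the longest half-life. Compared with the 1H-imidazol-2-yl group, the change is an at least 10-fold higher number from compound 1 to compound 4 (1.02 log units; beyond the scatter), but this is only a bound on the true change, as its starting point is a limit of the assay and not a number: the limit of < 0.0667 h in this assay, at which 1 of the 4 values shown sits.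

Which part of the new group goes with the longer half-life stays open, as the non-aromatic ring, the carbonyl and the double bonds enter together and no compound shown separates them. The compounds shown also leave open how a simple amine or a longer carbon chain would behave at this place, and whether the new group would have a similar effect on the core of compound 3.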